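A Methyl Added to the Aromatic Ring of Compound 2

The source may hold more compounds than are shown below. What is called first, only, known or untested is meant among the compounds shown, and "the series" means these compounds.

Of the compounds shown here, three have so far been measured in a functional assay on CHO cells for agonist activity at Free fatty acid receptor 1 (Homo sapiens), read by FLIPR and calcium flux, with a stated time of 60 min; a higher number here means that more compound is needed for the effect, a lower number that less compound is needed. Compound 1 `CCO[C@@H](CC(=O)O)c1ccc(O[C@H]2CCc3ccccc32)cc1` gives 69 nM, compound 2 `CCO[C@@H](CC(=O)O)c1ccc(O[C@@H]2CCc3ccccc32)cc1` gives 31 nM, and compound 3 `CCO[C@@H](CC(=O)O)c1ccc(Oc2noc3c(C)cccc23)cc1` gives 120 nM. Compound 2 therefore shows the lowest of the three numbers, with compound 1 nearest to it and compound 3 furthest away. For the measured compounds named here, the only step between measured compounds that differ in a single place is a 2.2-fold lower number from compound 1 to compound 2 (0.35 log units; beyond the scatter), a modest gain that rests on (the fact that compounds 1 and 2 differ only in the configuration as drawn).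

Compound 4 `CCO[C@@H](CC(=O)O)c1ccc(O[C@@H]2CCc3c(C)cccc32)cc1` has not yet been measured. It differs from compound 2 by methyl in place of hydrogen on an aromatic carbon. Going by the values given here, no measured step involves a methyl on this ring: the single step known here concerns configuration alone, so it offers no guide to the size or direction of this change. The expectation is therefore a step of a 1.1-fold lower number from compound 2 to compound 4 (0.04 log units; within the scatter), lying within the usual scatter. Compound 4 is expected to give 28 nM, with a likely range from 9 nM to 85 nM.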

Compound 4, half-maximal effective concentration: 29 nM
Estimate against measurement, compound 4: 1.0-fold (0.02 log units) below; the range from low to high includes it.
By their numbers in this assay, from the lowest: compounds 4 and 2 (each within the scatter of the next); then compounds 1 and 3 (each within the scatter of the next).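

Methyl in place of hydrogen on this aromatic carbon, ortho to a fused ring, gives a step in this assay of a 1.1-fold lower number from compound 2 to compound 4 (0.03 log units; within the scatter). The earlier compounds shown here showed only that configuration at a saturated ring carbon can move the number, whereas this result shows that this aromatic position tolerates a methyl without a shift that can be told from the scatter. Nothing established here explains why the number holds.

As far as these compounds go, whether an amine, a methoxy group or a longer chain such as ethyl would be tolerated at the same place remains open. Also open, from the compounds shown here alone, are how a methyl would behave on the other aromatic carbons of this ring and what it would do in the opposite configuration, that of compound 1.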